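This account rests on a few compounds, and the source may have more. Where it says the series, first, only, none or still open, it means among the compounds named here.

Measured compounds:

compound 1 `CCOC(=O)c1cc(=O)c2cc(CSC(=S)N(C(C)C)C(C)C)ccc2o1` gives > 25000 nM in a functional assay on SW480 cells (Homo sapiens) for antiproliferative activity, read by MTT assay, with a stated time of 72 h (on this read-out higher numbers stand for weaker inhibition and lower numbers for stronger inhibition), a limit rather than a number.
compound 2 `O=c1cc(CSC(=S)N2CCCCC2)oc2ccccc12` gives 13700 nM in this assay.
compound 3 `O=c1c(Cl)c(CSC(=S)N2CCCCC2)oc2ccccc12` gives 690 nM in this assay.

Going by the values given here, compound 3 stands lowest of the two numbers in this assay; compound 2 sits a 20-fold lower number from compound 2 to compound 3 (1.30 log units; beyond the scatter), the one measured step, which swaps hydrogen for chloro on an aromatic carbon of the shared core. Compound 1 is known only as the limit (the limit of > 25000 nM in this assay, at which 1 of the 3 values shown sits).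

Compound 4 `O=c1c(Cl)c(CSC(=S)N2CCOCC2)oc2ccccc12` differs from compound 3 by morpholin-4-yl in place of piperidin-1-yl on a thiocarbonyl carbon. Among the compounds with values here, no measured step touches this part of the molecule: the only step on record, a 20-fold lower number from compound 2 to compound 3 (1.30 log units; beyond the scatter), concerns the core and not the amine of the dithiocarbamate, so it gives no direct guide. With nothing pointing either way, the expectation for compound 4 is no step beyond the scatter, a 1.4-fold higher number from compound 3 to compound 4 (0.16 log units; within the scatter), while allowing for a somewhat weaker value. Compound 4 is therefore estimated at 1000 nM in this assay, between 350 nM and 3500 nM.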

Compound 4, half-maximal inhibitory concentration: 1800 nM
Beside the measured number, compound 4's estimate is 1.8-fold (0.26 log units) below it; the measured number falls inside the stated range.
By their numbers in this assay, from the lowest: compound 3; then compound 4; then compound 2. At a limit, above all of these: compound 1.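

Replacing piperidin-1-yl with morpholin-4-yl on a thiocarbonyl carbon gives a 2.6-fold higher number from compound 3 to compound 4 (0.42 log units; beyond the scatter) in this assay, so activity responds at this part of the molecule as well as on the shared core. The change is modest beside a 20-fold lower number from compound 2 to compound 3 (1.30 log units; beyond the scatter), which leaves the chloro-for-hydrogen swap on the core as the larger of the two steps on record. Nothing measured here gives a reason for the new step.

Whether the ring oxygen of morpholin-4-yl itself accounts for the step stays open; thiomorpholin-4-yl, 4-methylpiperazin-1-yl or an open-chain diethylamino group on the same carbon would bear on this. Also open, from the compounds shown here alone, is whether the same amine swap gives a step of this size on the core without chloro, as carried by compound 2.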